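Amide aryl swap: methylsulfonylphenyl back to chlorophenyl

The source may hold more compounds than are shown below. What is called first, only, known or untested is meant among the compounds shown, and "the series" means these compounds.

Measured so far:
compound 1 `O=C(Nc1ccc(Cl)c(-c2nnc3c(Cl)cccn23)c1)c1ccc(F)cc1Cl` — 75000 nM
compound 2 `CS(=O)(=O)c1ccc(C(=O)Nc2ccc(Cl)c(-c3nnc4c(Cl)cccn34)c2)cc1` — > 100000 nM

Both compounds share a core and differ only in the aryl group on the carbonyl carbon. In a functional assay on MDA-MB-231 cells (Homo sapiens) for antiproliferative activity, read by MTT assay, with stated times of 72 h and 4 h (a higher number here means a weaker inhibitor, a lower number a stronger inhibitor), compound 1 gives 75000 nM. The value for compound 2 is a limit of this assay, not a number: compound 2 gives > 100000 nM. For the measured compounds named here, the only measured step, an at least 1.3-fold higher number from compound 1 to compound 2 (0.12 log units; that floor lies within the scatter), is therefore bounded on one side only, and its floor lies within the scatter; the relevant evidence is the limit of > 100000 nM in this assay, at which 1 of the 2 values shown sits.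

Compound 3 `O=C(Nc1ccc(Cl)c(-c2nnc3c(Cl)cccn23)c1)c1ccccc1Cl` is not yet measured. It differs from compound 2 by 2-chlorophenyl in place of 4-(methylsulfonyl)phenyl on a carbonyl carbon. The 2-chlorophenyl of compound 3 resembles the 2-chloro-4-fluorophenyl of compound 1 more closely than the 4-(methylsulfonyl)phenyl of compound 2 does, so the measured step from compound 1 to compound 2 bears on this change only in reverse and only as a floor. Compound 3 is expected to land near the value of compound 1, that is 75000 nM, giving an estimated step of an at least 1.2-fold lower number from compound 2 to compound 3 (0.09 log units; that floor lies within the scatter). The estimate for compound 3 in this assay is 80000 nM, with a range from 35000 nM to 200000 nM; a reported limit rather than a number remains a real possibility.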

Compound 3, half-maximal inhibitory concentration: 59900 nM
For compound 3 the middle estimate is 1.3-fold (0.13 log units) above the measured one, and the stated range covers the measured number.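

In this assay, on these data alone, the change to 2-chlorophenyl from 4-(methylsulfonyl)phenyl on the carbonyl carbon gives an at least 1.6-fold lower number from compound 2 to compound 3 (0.22 log units; that floor lies within the scatter) and so leads from a limit of the assay to a number, but the size of this step stays open beyond its floor. The fluoro on the aryl group now has a step of its own: hydrogen in its place on the aromatic carbon gives a 1.3-fold lower number from compound 1 to compound 3 (0.10 log units; within the scatter) and the 2-chlorophenyl and 2-chloro-4-fluorophenyl groups cannot be told apart in this comparison. Any reading of the 4-(methylsulfonyl)phenyl group still rests on a single limit: the limit of > 100000 nM in this assay, at which 1 of the 3 values shown sits.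

The compounds shown leave open whether any change of the aryl group on this carbonyl carbon moves the number beyond the scatter. They also leave open how a carboxylic acid or an aminomethyl group on the phenyl ring would read, and whether the chlorine of 2-chlorophenyl can be replaced by hydrogen without a change beyond the scatter.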